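Compound 4: A Bromo Swap on a Weak Growth Inhibitor

The source may hold more compounds than are shown below. What is called first, only, known or untested is meant among the compounds shown, and "the series" means these compounds.

Measured so far in a functional assay on HT-29 cells (Homo sapiens) for inhibition, read by sulforhodamine B assay, with a stated time of 48 h; on this read-out higher numbers stand for weaker inhibition of growth and lower numbers for stronger inhibition of growth
Compound 1 (`CCOC(=O)c1nn(-c2ccccc2)c(-c2ccc(Br)cc2)c1CNC(C)(C)C`) 21800 nM; > 509000 nM (2 entries)
Compound 2 (`CC(C)(C)NCc1c(C(=O)O)nn(-c2ccccc2)c1-c1ccc(F)cc1`) > 680000 nM
Compound 3 (`CC(C)(C)NCc1c(C(=O)O)nn(-c2ccccc2)c1-c1ccc(Cl)cc1`) 353000 nM

Compound 1 has one number and one limit among its entries (the several entries of compound 1 in this assay, 21800 nM; > 509000 nM (2 entries)) and offers no single reference. For compound 2 the entry > 680000 nM is a limit. For the measured compounds named here, compound 3 at 353000 nM is the only compound here with a single number and no further entry.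

Compound 4 (`CC(C)(C)NCc1c(C(=O)O)nn(-c2ccccc2)c1-c1ccc(Br)cc1`) follows from compound 3 by one change (bromo in place of chloro on an aromatic carbon) that is bromo in place of chloro on an aromatic carbon. Going by the values given here, the one measured step of this kind is an at least 1.9-fold lower number from compound 2 to compound 3 (0.28 log units; that floor lies within the scatter) and it rests on a limit, so it gives no firm size. On that step, no change beyond the scatter and no direction is expected in this assay for the new compound. The estimated step is a 1.1-fold lower number from compound 3 to compound 4 (0.04 log units; within the scatter) and it is expected to stay within the scatter. Compound 4 is expected near 320000 nM with an estimated range from 120000 nM to 650000 nM in this read-out.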

Compound 4, concentration for 50% growth inhibition: > 585000 nM
Compound 4: only a limit was reported; the forecaster's own chance of this, stated with the estimate: 40%; middle value at least 1.8-fold (0.26 log units) away from the limit.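

Compound 4 completes a set of three carboxylic acids that differ only in the halogen on an aromatic carbon, para to a large group, and its entry in this assay is a limit: > 585000 nM. Going from 4-chlorophenyl to 4-bromophenyl gives an at least 1.6-fold higher number from compound 3 to compound 4 (0.21 log units; that floor lies within the scatter), so bromo in place of chloro shows no stronger inhibition of growth, although the floor of this step stays within the scatter and gives it no firm size. Compound 3 therefore remains the only one of these acids with a single number, and the step between the fluoro and bromo acids, both limits, cannot be read.

On these data alone, the true size of the chloro-to-bromo step remains open. So does how a methoxy group or a nitrile at the same place would read in this assay.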